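Chloro in Place of Bromo: A Small Expected Step

A few compounds are considered here, and "the series" means these few. Any claim that something is new, unique, unknown or untested is made for them only; others in the source may bear on it.

In a functional assay on Jurkat cells (Homo sapiens) for cytotoxicity, read by luminescence and CellTiter-Glo, with a stated time of 3 days (on this read-out higher numbers stand for weaker inhibition and lower numbers for stronger inhibition), compound 1 (`O=C(Nc1cc(C(F)(F)F)cc(C(F)(F)F)c1)c1cc(Br)c(-c2ccccc2)cc1O`) gives 680 nM, compound 2 (`O=C(Nc1cc(C(F)(F)F)cc(C(F)(F)F)c1)c1cc(Br)c(F)cc1O`) gives 700 nM and compound 3 (`O=C(Nc1cc(C(F)(F)F)cc(C(F)(F)F)c1)c1cc(Br)ccc1O`) gives 350 nM. Compound 1 thus stands within the scatter of both others. Compound 4 (`O=C(Nc1cc(C(F)(F)F)cc(C(F)(F)F)c1)c1cc(Cl)c(-c2ccccc2)cc1O`) has chloro in place of bromo on an aromatic carbon. Among the measured compounds shown here, no measured step makes this swap, so the evidence is indirect. The measured steps change another place on the core: a 1.0-fold higher number from compound 1 to compound 2 (0.01 log units; within the scatter), a 1.9-fold lower number from compound 1 to compound 3 (0.29 log units; within the scatter) and a 2.0-fold lower number from compound 2 to compound 3 (0.30 log units; within the scatter). Each stays within the scatter, so no step beyond the scatter is expected in this assay. For compound 4 the estimate is 650 nM, with an expected range of 300 nM to 1400 nM. The expected change is a 1.0-fold lower number from compound 1 to compound 4 (0.02 log units; within the scatter).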

Compound 4, half-maximal inhibitory concentration: 540 nM
Beside the measured number, compound 4's estimate is 1.2-fold (0.08 log units) above it; measured number inside the range.
By their numbers in this assay, from the lowest: compounds 3, 4, 1 and 2 (each within the scatter of the next).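

Among the compounds shown here, compound 4 gives the first direct look at the halogen on this carbon, which is para to a hydroxy group and ortho to a phenyl group. In this assay the swap gives a 1.3-fold lower number from compound 1 to compound 4 (0.10 log units; within the scatter) and so, with the phenyl group present, this read-out does not separate chloro from bromo here. Nothing shown gives a cause for this result. From the compounds shown here alone, whether chloro and bromo also match when fluoro or hydrogen replaces the phenyl group stays open. So does the effect of a nitrile or a methoxy group on this carbon.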